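The compounds below may be only part of what the source reports. "The series", "measured", "known", "first", "only" and "open" are said of these compounds alone.

Measured compounds in an ADME assay on PC-3 cells (Homo sapiens) for cytotoxicity, read by CCK-8 assay, with a stated time of 6 days; a higher number here means a weaker inhibitor, a lower number a stronger inhibitor:

Compound 1 `C[C@@H](Cn1ccc(-c2ccc(C#N)c(Cl)c2)n1)NC(=O)c1ccccc1` gives > 30000 nM, which is a limit of the assay and not a number.
Compound 2 `COC(=O)/C=C/C(=O)N[C@@H](C)Cn1ccc(-c2ccc(C#N)c(Cl)c2)n1` gives > 30000 nM, again a limit.
Compound 3 `CC(=O)c1ccc(S(=O)(=O)N[C@@H](C)Cn2ccc(-c3ccc(C#N)c(Cl)c3)n2)cc1` gives > 30000 nM, again a limit.

Compound 3 therefore stands where every measured member of the series stands, at the limit of > 30000 nM in this assay, at which 3 of the 3 values shown sit. Within the data shown here, the single step between measured compounds that differ in one place, a step that the two limits leave unreadable from compound 1 to compound 2, changes the group on the carbonyl carbon and cannot be read because both ends are limits; it says nothing about the size of any change.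

Compound 4 `C[C@@H](Cn1ccc(-c2ccc(C#N)c(Cl)c2)n1)NS(=O)(=O)c1cccnc1` differs from compound 3 by pyridin-3-yl in place of 4-acetylphenyl on a sulfonyl sulfur. Among the measured compounds shown here, no measured step touches the group on the sulfonyl sulfur, so the only guide is that all three measured compounds sit at the limit. The expectation is that compound 4 also stays at the limit, an estimated step that the limit leaves unreadable from compound 3 to compound 4. Compound 4 is thus estimated at 40000 nM in this assay, with a range from 20000 nM to 100000 nM, most likely reported once more as a limit only.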

Compound 4, half-maximal inhibitory concentration: > 30000 nM
Compound 4: only a limit was reported; the forecaster's own chance of this, stated with the estimate: 85%; the middle value lies beyond the limit too.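

Compound 4 gives > 30000 nM in this assay, which is a limit and not a number. The steps to compound 4 from compound 1, compound 2 and compound 3 therefore cannot be read. The compounds shown leave open whether changing the group on the amine nitrogen moves the value at all, with the whole series at one place: the limit of > 30000 nM in this assay, at which 4 of the 4 values shown sit.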